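A few compounds are considered here, and "the series" means these few. Any claim that something is new, unique, unknown or untested is made for them only; others in the source may bear on it.

Working notes on the series in a functional assay on K562 cells (Homo sapiens), read by MTT assay, with a stated time of 72 h; a lower number here means a stronger inhibitor, a higher number a weaker inhibitor. Among the measured compounds shown here, compound 3, `Cc1ncnc2c1c(-c1ccsc1)cn2[C@@H]1O[C@H](CO)[C@@H](O)[C@H]1O`, is the lower of the two numbers so far, giving 320 nM in this assay. For the measured compounds named here, compound 2, `Cc1ncnc2c1c(-c1cc3ccccc3o1)cn2[C@@H]1O[C@H](CO)[C@@H](O)[C@H]1O`, gives 19500 nM in this assay; the only measured step, a 61-fold lower number from compound 2 to compound 3 (1.78 log units; beyond the scatter), is large, and it shows how much the group on this aromatic carbon can move the number. Compound 1, `COc1ncnc2c1c(I)cn2[C@@H]1O[C@H](CO)[C@@H](O)[C@H]1O`, carries a methoxy group on the core in place of the methyl group and an iodo group on the aromatic carbon; in this assay compound 1 gives only the limit > 20000 nM, which is a limit of the assay and not a number (the limit of > 20000 nM in this assay, at which 1 of the 3 values shown sits).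

The next step leads to compound 4, `Cc1ncnc2c1c(I)cn2[C@@H]1O[C@H](CO)[C@@H](O)[C@H]1O`: iodo in place of thiophen-3-yl on an aromatic carbon. Going by the values given here, no measured step exchanges an aromatic ring for iodo, so the step from compound 2 to compound 3 bears on it only by showing the size of change this position allows. The closest hint is compound 1, whose iodo analogue sits at the limit in this assay. A large step toward a higher number is therefore expected, a 78-fold higher number from compound 3 to compound 4 (1.89 log units; beyond the scatter). For compound 4 the estimate in this assay is 25000 nM, with a range from 5000 nM to 100000 nM, and a considerable chance that only a limit is reported.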

Compound 4, half-maximal inhibitory concentration: 17800 nM
Compound 4: middle estimate off by 1.4-fold (0.15 log units), on the high side, within the range that was stated.
By their numbers in this assay, from the lowest: compound 3; then compounds 4 and 2 (each within the scatter of the next). At a limit, above all of these: compound 1.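

With the methyl group held on the shared core, iodo in place of thiophen-3-yl gives a 56-fold higher number from compound 3 to compound 4 (1.75 log units; beyond the scatter) in this assay, so the low number of compound 3 depends on the thiophen-3-yl group and does not come from the rest of the structure alone. The other step, a 1.1-fold lower number from compound 2 to compound 4 (0.04 log units; within the scatter), with iodo in place of 1-benzofuran-2-yl, leaves the two groups indistinguishable here; among the three groups shown on this aromatic carbon with the methyl core, thiophen-3-yl alone gives a clearly lower number, and neither a single iodine nor the larger 1-benzofuran-2-yl group does. With methyl in place of methoxy the step is an at least 1.1-fold lower number from compound 1 to compound 4 (0.05 log units; that floor lies within the scatter) and gives a floor only, so its size cannot be read. Compound 1 gives > 20000 nM, a limit and not a number: the limit of > 20000 nM in this assay, at which 1 of the 4 values shown sits.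

The compounds shown leave open whether the low number needs an aromatic ring at this place, as an amine or a longer chain on the same carbon would begin to show. They also leave open what methoxy in place of methyl does when thiophen-3-yl is present, since both compounds with that group pairing are absent from the set shown.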